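This account rests on a few compounds, and the source may have more. Where it says the series, first, only, none or still open, it means among the compounds named here.

Series values in a functional assay on A549 cells (Homo sapiens) for inhibition, read by MTT assay, with a stated time of 48 h; on this read-out lower numbers stand for stronger inhibition and higher numbers for weaker inhibition:
- compound 1 `CS(=O)(=O)c1ccc(-c2nc3ccccn3c2Sc2ccccc2)cc1`: 23200 nM
- compound 2 `Cc1ccc(-c2nc3ccccn3c2Sc2ccccc2)cc1`: 94300 nM
- compound 3 `C(=C/c1nc2ccccn2c1Sc1ccccc1)\c1ccccc1`: 16300 nM

Compound 3 at 16300 nM and compound 1 at 23200 nM lie within the usual scatter of each other. Compound 2 stands clearly apart from compound 3, with a 5.8-fold lower number from compound 2 to compound 3 (0.76 log units; beyond the scatter).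

The next compound is compound 4 `N#Cc1ccc(-c2nc3ccccn3c2Sc2ccccc2)cc1`, with 4-cyanophenyl in place of 2-phenylethenyl on an aromatic carbon.

For the measured compounds named here, two measured steps bear on this change. The first, a 5.8-fold lower number from compound 2 to compound 3 (0.76 log units; beyond the scatter), exchanges 4-methylphenyl for 2-phenylethenyl at the same place, so going back from 2-phenylethenyl to a substituted phenyl has a modest measured cost in that pair. The second, a 4.1-fold higher number from compound 1 to compound 2 (0.61 log units; beyond the scatter), shows that the group carried on that phenyl also moves the number by a modest amount. Going by the values given here, no nitrile-bearing compound has been measured, so compound 4 can only be placed by analogy with these two. Its value is expected between those of compound 1 at 23200 nM and compound 2 at 94300 nM, nearer the former.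

A small rise in this assay is therefore expected, near the edge of the scatter. The expected step is a 2.0-fold higher number from compound 3 to compound 4 (0.31 log units; beyond the scatter). For compound 4 the estimate is 33000 nM, with an expected range of 13000 nM to 85000 nM.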

Compound 4, half-maximal inhibitory concentration: 35200 nM
Beside the measured number, compound 4's estimate is 1.1-fold (0.03 log units) below it; the range from low to high includes it.
By their numbers in this assay, from the lowest: compounds 3, 1 and 4 (each within the scatter of the next, the first and the last beyond it); then compound 2.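

Working notes on the position on the five-membered aromatic ring: in this assay, 4-cyanophenyl in place of 2-phenylethenyl gives a modest step beyond the scatter (a 2.2-fold higher number from compound 3 to compound 4 (0.33 log units; beyond the scatter)), so this phenyl-bearing compound stays close to compound 1 rather than to compound 2. On that phenyl, cyano in place of methyl also gives a modest step beyond the scatter (a 2.7-fold lower number from compound 2 to compound 4 (0.43 log units; beyond the scatter)), while cyano in place of methylsulfonyl stays within the scatter (a 1.5-fold higher number from compound 1 to compound 4 (0.18 log units; within the scatter)), so among the three substituted phenyl compounds only the methyl of compound 2 stands apart, and nitrile and methylsulfonyl cannot be told apart in this read-out. No measurement at hand accounts for these steps.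

Still open, as far as these compounds go, is whether an amine or a carboxylic acid on that phenyl would fall with nitrile and methylsulfonyl or with methyl, and whether a saturated two-carbon chain bearing the phenyl would match 2-phenylethenyl. From the compounds shown here alone, the phenylsulfanyl group is the same in all four compounds, so the effect of an alkyl chain or an amine in its place remains unknown.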